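Adding Bromine to the Weakest Member of the Series

The compounds below may be only part of what the source reports. "The series", "measured", "known", "first", "only" and "open" are said of these compounds alone.

In a functional assay on cells (Cancer cell lines, Homo sapiens) for cytotoxicity, read by sulforhodamine B assay, with a stated time of 48 h (on this read-out lower numbers stand for stronger inhibition of growth and higher numbers for weaker inhibition of growth), compound 3 `COc1ccc(C2=NN(C3=NC(=O)/C(=C4\C(=O)Nc5ccccc54)S3)C(c3ccc(Cl)cc3)C2)cc1` gives 100000 nM, the highest number of the three measured compounds. For the measured compounds named here, compound 2 `O=C1N=C(N2N=C(c3ccccc3)CC2c2ccc(Cl)cc2)S/C1=C1/C(=O)Nc2ccccc21` gives 850 nM, and the single measured step, a 120-fold higher number from compound 2 to compound 3 (2.07 log units; beyond the scatter), shows a large loss. Compound 1 `COc1ccc(C2=NN(C3=NC(=O)/C(=C4\C(=O)Nc5ccc(Br)cc54)S3)C(c3ccc(OC)cc3)C2)cc1` gives 380 nM. Compound 4 `COc1ccc(C2=NN(C3=NC(=O)/C(=C4\C(=O)Nc5ccc(Br)cc54)S3)C(c3ccc(Cl)cc3)C2)cc1` differs from compound 3 by bromo in place of hydrogen on an aromatic carbon. Going by the values given here, no measured step tests this change by itself; compound 1, which also carries the bromo group, gives 380 nM, which hints that a bromine-bearing compound can reach a low number. The step from compound 3 to compound 4 is therefore expected to give a lower number, a 20-fold lower number from compound 3 to compound 4 (1.30 log units; beyond the scatter), though its size is uncertain. Compound 4 is estimated at 5000 nM, within 400 nM to 100000 nM.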

Compound 4, concentration for total growth inhibition: 370 nM
Compound 4: the middle estimate sits 14-fold (1.13 log units) above what was measured, and the stated range ends above it.
By their numbers in this assay, from the lowest: compounds 4 and 1 (each within the scatter of the next); then compound 2; then compound 3.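

Bromo in place of hydrogen on this carbon of the fused ring system brings a 270-fold lower number from compound 3 to compound 4 (2.43 log units; beyond the scatter) and is large, so one added atom here can change the read-out greatly. Once bromo is present, chloro in place of methoxy gives a 1.0-fold lower number from compound 1 to compound 4 (0.01 log units; within the scatter) and stays within the scatter, so this swap shows no measurable difference in this pair. Nothing measured here gives a reason for the large bromo step. On these data alone, it remains open whether a smaller fluoro, or an amine or a carboxylic acid, on the same carbon would act like bromo. As far as these compounds go, whether bromo brings a similar step in compound 2, which lacks the methoxy group, also remains open.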